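A few compounds are considered here, and "the series" means these few. Any claim that something is new, unique, unknown or untested is made for them only; others in the source may bear on it.

Of the compounds shown here, three with a shared core have been measured in a functional assay on the whole organism (B cells) with Mus musculus as the target; on this read-out higher numbers stand for larger maximal responses and lower numbers for smaller maximal responses. Compound 1 `C=CCn1c(=O)n(C2CCC(CO)C2)c2nc(N)nc(O)c21` gives 26%, compound 2 `CCOC(=O)Cn1c(=O)n(C2OC(CO)[C@@H](O)[C@H]2O)c2nc(N)nc(O)c21` gives 86%, and compound 3 `C=CCN1C(=C(C(=O)OCC)C(=O)OCC)N([C@H]2OC(CO)[C@H]3OC(C)(C)O[C@H]32)c2cc(N)nc(O)c21` gives 0%. Compound 2 therefore stands highest of the three, and its distance to compound 1, the nearest, is beyond the usual scatter, as is its distance to compound 3.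

Compound 4 `Nc1nc(O)c2c(n1)n(C1OC(CO)[C@@H](O)[C@H]1O)c(=O)n2Cc1ccc([N+](=O)[O-])cc1` has not yet been measured in this assay. It differs from compound 2 in one place: 4-nitrophenyl in place of ethoxycarbonyl on a saturated chain carbon bound to an aromatic nitrogen.

Among the measured compounds shown here, no pair differing in only one place has been measured, so the size of this step is unknown. A moderate fall is expected, a number 26 percentage points lower from compound 2 to compound 4 (beyond the scatter). For compound 4 a maximal response of about 60% is estimated, within a range from 25% to 95%.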

Compound 4, largest response reached (reported as maximal response), in percent of the reference or control that the assay uses: 147%
Estimate against measurement, compound 4: 87 percentage points below; measured number outside the range, above it.
By their numbers in this assay, from the lowest: compound 3; then compound 1; then compound 2; then compound 4.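

In this assay, swapping ethoxycarbonyl for 4-nitrophenyl on a saturated chain carbon bound to an aromatic nitrogen gives a number 61 percentage points higher from compound 2 to compound 4 (beyond the scatter) and so a large rise. Among the compounds shown here, this is the first single change that can be read at this place. It shows that an aromatic ring is accepted here and that the response can climb well past that of the ester.

Going by these compounds, whether the ring or its nitro group carries the rise stays open, and a plain benzyl or a 4-aminobenzyl group at this place would separate the two. Nothing available explains the rise.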